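A few compounds are considered here, and "the series" means these few. Any claim that something is new, unique, unknown or untested is made for them only; others in the source may bear on it.

Measured in an assay on blood for inhibition of Indoleamine 2,3-dioxygenase 1 (Homo sapiens); a higher number here means a weaker inhibitor, a lower number a stronger inhibitor:
compound 1 `Cc1nccc(N2c3ccc(C4(NC(=O)c5ccc(F)cc5)CC4)cc3[C@H]3CC[C@H]32)n1` gives 64 nM;
compound 2 `O=C(OC1CC1)N1CCc2nc(C3(C(=O)Nc4ccc(Cl)cc4)CCC3)ccc21` gives 90 nM;
compound 3 `Cc1nccc(N2c3ccc(C4(NC(=O)c5ccc(F)cc5)CC4)cc3[C@@H]3CC[C@@H]32)n1` gives 66 nM.

Compound 1 sits among the three numbers with no gap to either other compound beyond the scatter; compound 3, its mirror image, reads the same, and compound 2 is also close. Compound 4 `COC(=O)N1c2ccc(C3(NC(=O)c4ccc(F)cc4)CC3)cc2[C@H]2CC[C@H]21` is to be measured in this assay. The change from compound 1 is methoxycarbonyl in place of 2-methylpyrimidin-4-yl on a nitrogen on an aromatic ring in a ring. Going by the values given here, the only measured step, a 1.0-fold higher number from compound 1 to compound 3 (0.01 log units; within the scatter), concerns configuration alone the fact that compounds 1 and 3 differ only in the configuration as drawn and says nothing about the group on the ring nitrogen. Compound 2 carries a different carbamate on its ring nitrogen, on another core, and its value stands close to that of compound 1, so a carbamate here seems tolerated. For compound 4 a modest rise, if any, is expected: a 1.9-fold higher number from compound 1 to compound 4 (0.27 log units; within the scatter). Compound 4 is estimated at 120 nM, range 40 nM to 400 nM.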

Compound 4, half-maximal inhibitory concentration: 300 nM
The estimate for compound 4 lay 2.5-fold (0.40 log units) below the measured number; the measured number falls inside the stated range.
By their numbers in this assay, from the lowest: compounds 1, 3 and 2 (each within the scatter of the next); then compound 4.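

Going by these compounds alone, on a nitrogen on an aromatic ring in a ring, the group matters in this assay: methoxycarbonyl in place of 2-methylpyrimidin-4-yl gives a 4.7-fold higher number from compound 1 to compound 4 (0.67 log units; beyond the scatter) and is the first step beyond the scatter. The closeness of compound 2, with its different carbamate on another core, therefore does not carry over to the core of compound 1. Nothing shown bears on what lies behind this step. Still open, on these data alone, is how a phenyl or an acetyl on this nitrogen would read, which would separate loss of the 2-methylpyrimidin-4-yl ring from entry of the methoxycarbonyl.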